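Trifluoromethyl for chloro on the fused ring system

The source may report more compounds than this note shows. Statements on the series, on what has been measured and on what is new or still open speak of the compounds shown alone.

Among the compounds with values here, compound 1 `NC(=S)N/N=C1/C(=O)N(CN2CCN(c3ccnc4cc(Cl)ccc34)CC2)c2cccc(Cl)c21` is one of two compounds measured in an ADME assay on 184B5 cells (Homo sapiens) for cytotoxicity, read by sulforhodamine B assay, with a stated time of 48 h; a higher number here means a weaker inhibitor of growth, a lower number a stronger inhibitor of growth. In this assay compound 1 gives 20700 nM, the lower of the two numbers. Compound 2 `NC(=S)N/N=C1/C(=O)N(CN2CCN(c3ccnc4cc(Cl)ccc34)CC2)c2ccccc21` gives 28800 nM in this assay, and the change from compound 1 to compound 2 is hydrogen in place of chloro on an aromatic carbon, giving a 1.4-fold higher number from compound 1 to compound 2 (0.14 log units; within the scatter). The two values thus sit within the scatter of each other, and no order between them can be read.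

Compound 3 `NC(=S)N/N=C1/C(=O)N(CN2CCN(c3ccnc4cc(C(F)(F)F)ccc34)CC2)c2cccc(Cl)c21` differs from compound 1 by trifluoromethyl in place of chloro on an aromatic carbon. Within the data shown here, the chloro that leaves here is not the one lost from compound 1 to compound 2, so the only measured step does not touch the same group; it shows merely that a change of one halogen on the shared core left this assay unmoved. Among the measured compounds shown here, with no direct precedent, a step beyond the scatter is not expected, and compound 3 is estimated at 20000 nM with a range from 8000 nM to 50000 nM, corresponding to an expected step of a 1.0-fold lower number from compound 1 to compound 3 (0.01 log units; within the scatter).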

Compound 3, concentration for 50% growth inhibition: 87800 nM
Compound 3: the middle estimate sits 4.4-fold (0.64 log units) below what was measured, outside the stated range (above it).
By their numbers in this assay, from the lowest: compounds 1 and 2 (each within the scatter of the next); then compound 3.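

In this assay, trifluoromethyl in place of chloro on the six-membered aromatic ring of carbon only, part of a fused or bridged system of two rings, gives a 4.2-fold higher number from compound 1 to compound 3 (0.63 log units; beyond the scatter), so a single change on the shared core can move this read-out beyond the scatter, and in the direction of a weaker inhibitor of growth. The other one-place step in the series, a 1.4-fold higher number from compound 1 to compound 2 (0.14 log units; within the scatter), replaces a different chloro and stays within the scatter, so the two chloro-bearing positions are not interchangeable in what these two changes show. The change here replaces one heavy atom with four and alters no count of hydrogen-bond donors, hydrogen-bond acceptors or net charge, and no measurement at hand explains the step.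

A single replacement at this position cannot show whether the step is specific to trifluoromethyl or would also appear with a methoxy group, an amine or a nitrile on the same carbon. Going by these compounds, it also remains open whether the same replacement gives a similar step when hydrogen stands in place of the other chloro on the shared core.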